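The source may report more compounds than this note shows. Statements on the series, on what has been measured and on what is new or still open speak of the compounds shown alone.

Compound 1 `Nc1nc2c(ncn2/C=C2/C[C@@H]2[C@@H](O)CO)c(=O)[nH]1`: > 300000 nM
Compound 2 `Nc1nc2c(ncn2/C=C2/C[C@H]2[C@@H](O)CO)c(=O)[nH]1`: 299000 nM

Among the measured compounds shown here, in an ADME assay on HFF cells (Homo sapiens) for cytotoxicity, read by neutral red uptake (a lower number here means that less compound is tolerated, a higher number that more compound is tolerated), compound 2 gives 299000 nM, the only true number so far. Compound 1 gives > 300000 nM, which is a limit of the assay and not a number.

Compound 3 `Nc1nc2c(ncn2/C=C2\C[C@H]2[C@H](O)CO)c(=O)[nH]1` has not yet been measured. Its difference from compound 2 is the two compounds have the same atoms and bonds and differ only in configuration as drawn: 2 of 3 stereo elements differ; a stereocentre at a saturated chain carbon is drawn R in compound 2 and S in compound 3; a double bond is drawn Z in compound 2 and E in compound 3. Nothing leaves and nothing enters, so the two compounds have the same atoms and bonds and differ only in configuration as drawn.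

For the measured compounds named here, one measured step bears on this change: a number no higher from compound 1 to compound 2 (the limit leaves the size open). Its size cannot be read. It also concerns a stereocentre at a saturated ring carbon, not the saturated chain carbon or the double bond that change here. It therefore offers no measured size to carry over, and the best starting point is compound 2 at 299000 nM. No step beyond the usual scatter is expected, and the expected change is a 1.0-fold higher number from compound 2 to compound 3 (0.00 log units; within the scatter). For compound 3 the estimated value is 300000 nM, with an expected range of 150000 nM to 500000 nM.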

Compound 3, half-maximal cytotoxic concentration: > 300000 nM
Compound 3: only a limit was reported; the forecaster's own chance of this, stated with the estimate: 60%; the middle value sits exactly at the limit.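

In this assay compound 3 gives > 300000 nM, which is a limit of the assay and not a number. This is the first compound shown with the double bond drawn E and the saturated chain carbon drawn S, and these two changes together bring a number no lower from compound 2 to compound 3 (the limit leaves the size open). The steps among the three compounds cannot be read, because the limit leaves their size open: the limit of > 300000 nM in this assay, at which 2 of the 3 values shown sit.

What the compounds leave open is how far their true values lie from one another, and what each of the two changes made together between compound 2 and compound 3 would do alone. They also leave open whether this assay would give a lower number for a compound with the same stereo elements that carries an amine, a carboxylic acid or a longer chain in place of the two hydroxyl groups.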